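Benzyl substituent change in the rhodanine series: cytotoxicity outlook

This account rests on a few compounds, and the source may have more. Where it says the series, first, only, none or still open, it means among the compounds named here.

Compound 1 `Cc1cc(/C=C2\SC(=S)N(Cc3ccc(C(=O)O)cc3)C2=O)c(C)n1-c1ccc(O)c(C(=O)O)c1` gives 105000 nM in an ADME assay on MT2 cells (Homo sapiens) for cytotoxicity, read by XTT assay, with a stated time of 4 days; a higher number here means that more compound is tolerated, a lower number that less compound is tolerated. Compound 2 `Cc1cc(/C=C2\SC(=S)N(Cc3cccc(C(=O)O)c3)C2=O)c(C)n1-c1ccc(O)c(C(=O)O)c1` gives > 100000 nM in this assay, and this value is a limit of the assay rather than a number. On the numbers shown, compound 2 therefore stands at the tolerated end without a readable figure. Among the measured compounds shown here, the only measured step, a step that the limit leaves unreadable from compound 1 to compound 2, cannot be sized, because the limit of > 100000 nM in this assay, at which 1 of the 2 values shown sits, leaves the second value unread.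

Compound 3 `Cc1cc(/C=C2\SC(=S)N(Cc3ccccc3Br)C2=O)c(C)n1-c1ccc(O)c(C(=O)O)c1` carries the change (2-bromophenyl in place of 3-carboxyphenyl on a saturated chain carbon bound to an amide-type nitrogen in a ring). For the measured compounds named here, no measured step bears directly on this change, and the one neighbouring step is unreadable, so no direction beyond the scatter is claimed. Compound 3 is expected to remain near the tolerated end, with an estimated step of an at least 1.6-fold lower number from compound 2 to compound 3 (0.22 log units; that floor lies within the scatter) that is small. The estimate for compound 3 in this assay is 60000 nM, with a range from 20000 nM to 150000 nM.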

Compound 3, half-maximal cytotoxic concentration: 25700 nM
Compound 3: middle estimate off by 2.3-fold (0.37 log units), on the high side; measured number inside the range.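

At this place, on a saturated chain carbon bound to an amide-type nitrogen in a ring, the benzyl substituent does move the read-out in this assay: 2-bromophenyl gives an at least 3.8-fold lower number from compound 2 to compound 3 (0.59 log units; beyond the scatter) and a 4.1-fold lower number from compound 1 to compound 3 (0.61 log units; beyond the scatter) in the two comparisons with the carboxyphenyl compounds. Among the compounds shown here, compound 3, with no carboxylic acid on the benzyl group, is the first compound with a number clearly lower than both of them. Between the 3-carboxyphenyl and 4-carboxyphenyl compounds themselves, the step still cannot be read: the limit of > 100000 nM in this assay, at which 1 of the 3 values shown sits.

The change to compound 3 removes the carboxylic acid and brings in bromine at once, so the compounds shown do not separate the two. An unsubstituted benzyl or a 2-chlorophenyl at this place would bear on that question.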